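Swapping the cyclic sulfonamide for a cyclic urea on compound 1

The source may report more compounds than this note shows. Statements on the series, on what has been measured and on what is new or still open speak of the compounds shown alone.

Three compounds share a core and are compared in an assay on CHO-K1 cells for displacement of a labelled ligand from melanin-concentrating hormone receptor 1 (Homo sapiens), read by scintillation proximity assay, with a stated time of 2 h; a lower number here means a stronger inhibitor, a higher number a weaker inhibitor. Compound 1 `Cc1nc(N2CCC(N3CCCS3(=O)=O)CC2)nc2ccc(NC(=O)/C=C/c3ccc(OC(F)(F)F)cc3)cc12` gives 4 nM, the lowest number of the three and therefore the strongest inhibitor in this set, since both other compounds lie beyond the scatter. Compound 3 `CCCC1(O)CCN(c2nc(C)c3cc(NC(=O)/C=C/c4ccc(Cl)cc4)ccc3n2)CC1`, the nearest, gives 245 nM in this assay. Compound 2 `Cc1nc(N2CCC(O)(C3CC3)CC2)nc2ccc(NC(=O)/C=C/c3ccc(Cl)cc3Cl)cc12`, the furthest, gives 620 nM in this assay.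

Compound 4 `Cc1nc(N2CCC(N3CCNC3=O)CC2)nc2ccc(NC(=O)/C=C/c3ccc(OC(F)(F)F)cc3)cc12` has not yet been measured. It differs from compound 1 in one place: a group of 6 heavy atoms (3 carbon, 2 nitrogen, 1 oxygen; one five-membered non-aromatic ring with 2 hetero atoms) in place of a group of 7 heavy atoms (3 carbon, 1 nitrogen, 2 oxygen, 1 sulfur; one five-membered non-aromatic ring with 2 hetero atoms), on a saturated ring carbon. The group that leaves and the group that enters are of similar size and each holds one five-membered non-aromatic ring with 2 hetero atoms; the entering group brings 1 hydrogen-bond donor where the leaving one had none.

Within the data shown here, no step between two measured compounds shows this change, so the expectation rests on the closeness of the two groups. A small step, a 2.0-fold higher number from compound 1 to compound 4 (0.30 log units; within the scatter), towards a slightly higher number is expected, probably not beyond the scatter. Compound 4 is estimated at 8 nM in this assay, within a range from 2 nM to 30 nM.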

Compound 4, half-maximal inhibitory concentration: 66 nM
Compound 4: middle estimate off by 8.3-fold (0.92 log units), on the low side, outside the stated range (above it).
By their numbers in this assay, from the lowest: compound 1; then compound 4; then compound 3; then compound 2.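

Exchanging the cyclic sulfonamide of compound 1 for 2-oxoimidazolidin-1-yl on the saturated ring carbon gives a 17-fold higher number from compound 1 to compound 4 (1.22 log units; beyond the scatter) in this assay and so shows that this position responds strongly to which ring it carries. Among these compounds, two groups with the same ring size and nearly the same heavy-atom count are therefore not interchangeable here, a point the earlier compounds, which differ in more than one place, could not show. Nothing measured here gives a cause for this step, and the gain of a hydrogen-bond donor cannot be separated from the exchange of the sulfonyl group for a carbonyl.

The compounds shown leave open how a 2-oxoimidazolidin-1-yl ring carrying a methyl on its free ring nitrogen would compare with compound 4 and compound 1. They also leave open how an open-chain group such as a methanesulfonamide would behave at this carbon.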